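Swapping the pyrimidine for a substituted phenyl ring

This account rests on a few compounds, and the source may have more. Where it says the series, first, only, none or still open, it means among the compounds named here.

Compound 1, `COc1cccc(-c2c(C)nn(-c3nc(-c4ccc(Cl)c(Cl)c4)c(SC(C)C)s3)c2C(=O)O)c1`: 14000 nM
Compound 2, `Cc1nn(-c2nc(-c3ccc(Cl)c(Cl)c3)c(SC(C)C)s2)c(C(=O)O)c1-c1ccccc1`: 3000 nM
Compound 3, `Cc1nn(-c2nc(-c3ccc(Cl)c(Cl)c3)c(SC(C)C)s2)c(C(=O)O)c1-c1cncnc1`: 22000 nM

All three compounds were tested in a functional assay on BJAB cells (Homo sapiens) for antiproliferative activity, with a stated time of 4 days; a higher number here means that more compound is needed for the effect, a lower number that less compound is needed. Compound 3 has the highest of the three numbers, although its gap to compound 1 lies within the usual scatter; against compound 2 the gap is clear, as a 7.3-fold higher number from compound 2 to compound 3 (0.87 log units; beyond the scatter) shows.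

Compound 4, `Cc1nn(-c2nc(-c3ccc(Cl)c(Cl)c3)c(SC(C)C)s2)c(C(=O)O)c1-c1cc(C#N)cc(C(F)(F)F)c1`, differs from compound 3 in one place: 3-cyano-5-(trifluoromethyl)phenyl in place of pyrimidin-5-yl on an aromatic carbon. Among the measured compounds shown here, two measured steps bear on this. Going the other way along a 7.3-fold higher number from compound 2 to compound 3 (0.87 log units; beyond the scatter), a carbon-only ring in place of the pyrimidin-5-yl gave a modestly lower number. Yet a 4.7-fold lower number from compound 1 to compound 2 (0.67 log units; beyond the scatter) shows that a methoxy on that phenyl ring made the number modestly higher than bare phenyl. The entering 3-cyano-5-(trifluoromethyl)phenyl is a carbon-only ring carrying two groups, so the expectation is a number lower than that of compound 3 but not reaching compound 2. The expected step is a 2.8-fold lower number from compound 3 to compound 4 (0.44 log units; beyond the scatter). Compound 4 is therefore estimated at 8000 nM, with a range from 2500 nM to 25000 nM.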

Compound 4, half-maximal effective concentration: 3600 nM
Compound 4: middle estimate off by 2.2-fold (0.35 log units), on the high side; the range from low to high includes it.
By their numbers in this assay, from the lowest: compounds 2 and 4 (each within the scatter of the next); then compounds 1 and 3 (each within the scatter of the next).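

In this assay, a phenyl ring at this position can carry two groups and still match the bare ring, as 3-cyano-5-(trifluoromethyl)phenyl in place of phenyl gives a 1.2-fold higher number from compound 2 to compound 4 (0.08 log units; within the scatter). The higher number seen with methoxy therefore does not apply to every substituted phenyl ring, since 3-cyano-5-(trifluoromethyl)phenyl in place of 3-methoxyphenyl gives a 3.9-fold lower number from compound 1 to compound 4 (0.59 log units; beyond the scatter). The same ring in place of pyrimidin-5-yl gives a 6.1-fold lower number from compound 3 to compound 4 (0.79 log units; beyond the scatter), so a carbon-only ring can again give a lower number than the pyrimidine, although compound 1 goes against this.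

Nothing available here gives a reason for these differences. Still open, from the compounds shown here alone, is whether a nitrile or a trifluoromethyl group alone would give the same result, and how an amine or a hydroxyl group on the phenyl ring would compare.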